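The source may report more compounds than this note shows. Statements on the series, on what has been measured and on what is new or still open speak of the compounds shown alone.

Measured so far in a functional assay on MCF7 cells (Homo sapiens) for cytotoxicity, read by MTT assay, with a stated time of 72 h; a higher number here means a weaker inhibitor, a lower number a stronger inhibitor
- compound 1 `CN(C)CCCCCn1c2c(c3ccccc31)C(=O)c1c[n+]([O-])c3ccccc3c1C2=O` gives 200 nM
- compound 2 `CCCCN1CCN(CCCCn2c3c(c4ccccc42)C(=O)c2c[n+]([O-])c4ccccc4c2C3=O)CC1` gives 6900 nM

Compound 2 holds the higher number of the two. Among the compounds with values here, the only measured step shows a 35-fold higher number from compound 1 to compound 2 (1.54 log units; beyond the scatter) for 4-butylpiperazin-1-yl in place of (dimethylamino)methyl on a saturated chain carbon, four bonds along the chain from an aromatic nitrogen. Compound 3 `O=C1c2c[n+]([O-])c3ccccc3c2C(=O)c2c1c1ccccc1n2CCN1CCCCC1` follows with the change piperidin-1-yl in place of 2-(4-butylpiperazin-1-yl)ethyl on a saturated chain carbon, two bonds along the chain from an aromatic nitrogen which puts piperidin-1-yl in place of 2-(4-butylpiperazin-1-yl)ethyl on a saturated chain carbon, two bonds along the chain from an aromatic nitrogen. Compound 3 no longer carries the 4-butylpiperazin-1-yl group of that large step, so a clear move to a lower number is expected in this assay although a single step is a rough guide. The expected step is a 7.7-fold lower number from compound 2 to compound 3 (0.88 log units; beyond the scatter) on this estimate. Compound 3 is estimated at 900 nM with an expected range of 200 nM to 4000 nM for now.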

Compound 3, half-maximal inhibitory concentration: 620 nM
Estimate against measurement, compound 3: 1.5-fold (0.16 log units) above; the range from low to high includes it.
By their numbers in this assay, from the lowest: compound 1; then compound 3; then compound 2.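

Piperidin-1-yl in place of 2-(4-butylpiperazin-1-yl)ethyl, on a saturated chain carbon two bonds along the chain from an aromatic nitrogen, gives an 11-fold lower number from compound 2 to compound 3 (1.05 log units; beyond the scatter) in this assay and recovers much of the large rise seen for compound 2, so a ring amine at the end of the side chain is compatible with the number that compound 3 gives (620 nM). Piperidin-1-yl in place of 3-(dimethylamino)propyl at that same place still gives a 3.1-fold higher number from compound 1 to compound 3 (0.49 log units; beyond the scatter) in this assay as a modest step, which leaves compound 1 with the lowest number of the three. Nothing at hand bears on why these steps differ in size.

Going by these compounds, each step changes the terminal amine and the chain together, so their separate shares remain open. Piperidin-1-yl on a longer chain, or morpholin-4-yl or an unsubstituted piperazine on the chain of compound 3, would help to separate them.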